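This account rests on a few compounds, and the source may have more. Where it says the series, first, only, none or still open, it means among the compounds named here.

Measured compounds:
compound 1, `Fc1ccc(/C=N/Nc2nc(-c3cc(C(F)(F)F)cc(C(F)(F)F)c3)cs2)cc1F`, 62800 nM
compound 2, `COc1ccccc1-c1csc(N/N=C/c2cc(Br)c(OC)c(OC)c2)n1`, > 100000 nM
compound 3, `COc1cc(/C=N/Nc2nc(-c3ccc(F)c(F)c3)cs2)cc(Br)c1OC`, 21200 nM

In a functional assay on Caco-2 cells (Homo sapiens) for inhibition, read by MTT assay, with a stated time of 48 h (a higher number here means a weaker inhibitor, a lower number a stronger inhibitor), compound 1 gives 62800 nM, the highest of the two numbers on record; the nearest is compound 3, which gives 21200 nM, a value lower than compound 1 beyond the scatter. Compound 2 is reported only as a limit of this assay, > 100000 nM, as noted in the limit of > 100000 nM in this assay, at which 1 of the 3 values shown sits.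

The unmeasured compound 4, `COc1cc(/C=N/Nc2nc(-c3cc(C(F)(F)F)cc(C(F)(F)F)c3)cs2)cc(Br)c1OC`, differs from compound 1 by 3-bromo-4,5-dimethoxyphenyl in place of 3,4-difluorophenyl on a carbon with a double bond to nitrogen.

Within the data shown here, the one measured step, an at least 4.7-fold lower number from compound 2 to compound 3 (0.67 log units; beyond the scatter), concerns the aryl group on the shared core rather than the group on the carbon with a double bond to nitrogen, so it does not bear directly on the change from compound 1 to compound 4. Among the measured compounds shown here, the only guidance is that compound 3, which carries the same 3-bromo-4,5-dimethoxyphenyl that enters here, gives 21200 nM, a lower number than compound 1. A small step downward is therefore expected, a 1.6-fold lower number from compound 1 to compound 4 (0.20 log units; within the scatter), though it may well stay within the scatter. Compound 4 is estimated at 40000 nM, in the range 12000 nM to 100000 nM.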

Compound 4, half-maximal inhibitory concentration: > 100000 nM
Compound 4 gave a limit, no number; the forecaster's own chance of this, stated with the estimate: 20%; middle value at least 2.5-fold (0.39 log units) away from the limit.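

In this assay, among these compounds, the change from 3,4-difluorophenyl to 3-bromo-4,5-dimethoxyphenyl on a carbon with a double bond to nitrogen is the first step seen at this position, and it gives an at least 1.5-fold higher number from compound 1 to compound 4 (0.20 log units; that floor lies within the scatter), so it brings no lower number, while the real size of the step stays unfixed. Compound 4 is reported only as a limit, > 100000 nM, a reading it shares with compound 2: the limit of > 100000 nM in this assay, at which 2 of the 4 values shown sit. The 3-bromo-4,5-dimethoxyphenyl group therefore does not settle the reading on its own, since compound 3, which also carries it, gives a measured 21200 nM.

The compounds shown leave open how large the step from 3,4-difluorophenyl to 3-bromo-4,5-dimethoxyphenyl really is, and whether it would read the same with the other aryl groups on the shared core. They also leave open what a quite different group on this carbon, such as a phenyl ring bearing an amine or a carboxylic acid, would do to the number in this assay.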